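The compounds below may be only part of what the source reports. "The series", "measured", "known", "first", "only" and "open" are said of these compounds alone.

Of the compounds shown here, three that share one core have been tested in a functional assay on HCT-116 cells (Homo sapiens) for antiproliferative activity, read by MTT assay, with a stated time of 72 h (on this read-out lower numbers stand for stronger inhibition and higher numbers for weaker inhibition), and all three sit at the same place. Compound 1 `Cc1ccc(-c2cn(C/C=C3\OC(=O)C(OCc4ccccc4)=C3OCc3ccccc3)nn2)cc1` gives > 100000 nM, which is a limit of the assay and not a number. Compound 2 `COc1ccccc1-c1cn(C[C@H](O)[C@H]2OC(=O)C(OCc3ccccc3)=C2OCc2ccccc2)nn1` gives > 100000 nM, again a limit rather than a measured value. Compound 3 `CC(C)(C)OC(=O)N1CCN(C(=S)SCc2cn(C[C@H](O)[C@H]3OC(=O)C(OCc4ccccc4)=C3OCc3ccccc3)nn2)CC1` gives > 100000 nM, also a limit. Compound 2 therefore stands exactly where every value shown stands, with nothing to rank it against, since (the limit of > 100000 nM in this assay, at which 3 of the 3 values shown sit). Among the measured compounds shown here, no pair of measured compounds that differ in a single place exists here, so no measured change can be pointed to.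

Compound 4 `CCCCCCCCCCc1cn(C[C@H](O)[C@H]2OC(=O)C(OCc3ccccc3)=C2OCc2ccccc2)nn1` has not yet been measured in this assay. It differs from compound 2 in one place: decyl in place of 2-methoxyphenyl on an aromatic carbon. For the measured compounds named here, nothing measured so far tells how such a change acts on this read-out, and no direction can be taken from values that all sit at the limit. The step from compound 2 to compound 4 is therefore expected to be a number no higher from compound 2 to compound 4 (the limit leaves the size open), with no change beyond the scatter the likeliest outcome. Compound 4 is expected to give about 100000 nM in this assay, within a range from 20000 nM to 300000 nM, and most probably again only a limit.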

Compound 4, half-maximal inhibitory concentration: 28800 nM
Compound 4: middle estimate off by 3.5-fold (0.54 log units), on the high side; the range from low to high includes it.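

In this assay, the aromatic carbon of the five-membered aromatic ring with 3 nitrogen proves to be a place where a change can be read: decyl in place of 2-methoxyphenyl gives an at least 3.4-fold lower number from compound 2 to compound 4 (0.54 log units; beyond the scatter). The shared core can therefore give a measured number, since compound 4, at 28800 nM, carries one, and the change that brings this replaces a ring-bearing group with an open chain. The value of compound 2 is a limit and not a number, and the full size of this step stays open because of that limit: the limit of > 100000 nM in this assay, at which 3 of the 4 values shown sit.

The compounds shown leave open whether it is the decyl chain itself that matters or simply the departure of 2-methoxyphenyl, and a plain phenyl, a shorter chain such as hexyl or a longer chain such as dodecyl at the same carbon would each bear on that question. They also leave open whether an amine or a carboxylic acid at the end of the chain would keep a measurable number in this assay, and whether decyl would act in the same way on the other parts of the core seen in compound 1 and compound 3.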